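Lengthening the acyl chain of compound 1

The compounds below may be only part of what the source reports. "The series", "measured", "known", "first", "only" and "open" are said of these compounds alone.

Of the compounds shown here, three sharing one core have been measured in a functional assay on MGC-803 cells (Homo sapiens) for inhibition, read by MTT assay, with a stated time of 48 h; on this read-out higher numbers stand for weaker inhibition and lower numbers for stronger inhibition. Compound 1 `CCC(=O)N(Cc1ccc(OC)c(O)c1)c1cc(OC)c(OC)c(OC)c1` gives 50 nM, the lowest of the three numbers. Compound 2 `C/C=C/C(=O)N(Cc1ccc(OC)cc1)c1cc(OC)c(OC)c(OC)c1` gives 450 nM, and compound 3 `COc1ccc(CNc2cc(OC)c(OC)c(OC)c2)cc1Cl` gives 46200 nM; both differ from compound 1 in more than one place, so no single step can be read from them. Compound 1 thus stands clearly apart from the other two, with gaps that lie beyond the scatter in each case.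

Compound 4 `CC/C=C/C(=O)N(Cc1ccc(OC)c(O)c1)c1cc(OC)c(OC)c(OC)c1` has not yet been measured. It differs from compound 1 in one place: but-1-en-1-yl in place of ethyl on a carbonyl carbon. Going by the values given here, no measured pair shows this change on its own, so its effect is unknown from these data. The expected step from compound 1 to compound 4 is therefore small, a 1.6-fold higher number from compound 1 to compound 4 (0.20 log units; within the scatter), leaning slightly towards weaker inhibition but not clearly beyond the scatter. Compound 4 is estimated at 80 nM, with a likely range from 25 nM to 300 nM.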

Compound 4, half-maximal inhibitory concentration: 58 nM
Compound 4: middle estimate off by 1.4-fold (0.14 log units), on the high side, within the range that was stated.
By their numbers in this assay, from the lowest: compounds 1 and 4 (each within the scatter of the next); then compound 2; then compound 3.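

In this assay putting but-1-en-1-yl in place of ethyl on a carbonyl carbon gives a 1.2-fold higher number from compound 1 to compound 4 (0.06 log units; within the scatter) and leaves the two compounds indistinguishable on this read-out. Going by these compounds alone, this position therefore accepts the larger chain, with its added carbons and its double bond, without a step beyond the scatter, something the earlier compounds, each differing from compound 1 in more than one place, could not show. No independent measurement offers an explanation for this result.

The chain length and the double bond changed together, so the compounds shown do not separate their contributions, and a saturated butyl group would be needed to do so. They also leave open how far this tolerance extends, for instance to a longer chain such as octyl or to a chain ending in an amine or a carboxylic acid.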